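The source may report more compounds than this note shows. Statements on the series, on what has been measured and on what is new or still open speak of the compounds shown alone.

Measured compounds:
compound 1, `CCC(C)(C)Cc1c[nH]c(CCc2ccc(-c3cccc(C)n3)cc2)n1`, giving 6.3 nM;
compound 2, `CCC(C)(C)Cc1c[nH]c(CCc2ccc(-n3cccn3)cc2)n1`, giving 33 nM;
compound 3, `CCC(C)(C)Cc1c[nH]c(CCc2ccc(-n3ccnn3)cc2)n1`, giving 390 nM.

All three were tested in an in vitro assay on CHO cells for displacement of a labelled ligand from Bombesin receptor subtype-3 (Homo sapiens), read by scintillation counting, with a stated time of 2 h; on this read-out higher numbers stand for weaker inhibition and lower numbers for stronger inhibition. Compound 3 stands with the highest number of the three measured: the step of a 12-fold higher number from compound 2 to compound 3 (1.07 log units; beyond the scatter) is large, and the step of a 62-fold higher number from compound 1 to compound 3 (1.79 log units; beyond the scatter) is larger still, so compound 3 is the weakest of the three by a margin beyond the scatter in both directions.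

Compound 4, `CCC(C)(C)Cc1c[nH]c(CCc2ccc(-c3cnccn3)cc2)n1`, differs from compound 3 by pyrazin-2-yl in place of 1H-1,2,3-triazol-1-yl on an aromatic carbon. Going by the values given here, two measured steps bear on this change. Compound 1 carries a six-membered ring with one nitrogen joined to the core through a ring carbon, and the step of a 62-fold higher number from compound 1 to compound 3 (1.79 log units; beyond the scatter) shows how far the number rose when that ring gave way to the 1H-1,2,3-triazol-1-yl of compound 3. Compound 2 carries a five-membered ring joined through nitrogen, as compound 3 does, and the step of a 12-fold higher number from compound 2 to compound 3 (1.07 log units; beyond the scatter) was smaller. Compound 4 returns to a six-membered ring joined through carbon, closer in kind to compound 1 than to compound 2 or compound 3. Among the compounds with values here, a large drop in the number is therefore expected from compound 3 to compound 4, short of a full return to compound 1 since the second nitrogen of pyrazin-2-yl has no measured counterpart here.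

The step expected for compound 4 is a 20-fold lower number from compound 3 to compound 4 (1.29 log units; beyond the scatter). For compound 4 the estimate is 20 nM, in a range from 5 nM to 80 nM.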

Compound 4, half-maximal inhibitory concentration: 51 nM
Beside the measured number, compound 4's estimate is 2.6-fold (0.41 log units) below it, within the range that was stated.
By their numbers in this assay, from the lowest: compound 1; then compounds 2 and 4 (each within the scatter of the next); then compound 3.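

In this assay, pyrazin-2-yl in place of 1H-1,2,3-triazol-1-yl gives a 7.6-fold lower number from compound 3 to compound 4 (0.88 log units; beyond the scatter), so a six-membered ring joined through carbon recovers part of the ground lost with the triazole, though not all of it. The two other comparisons show that ring size and the joining atom do not settle the number on their own: a 1.5-fold higher number from compound 2 to compound 4 (0.19 log units; within the scatter) leaves pyrazin-2-yl and the five-membered 1H-pyrazol-1-yl of compound 2 indistinguishable, whereas an 8.1-fold higher number from compound 1 to compound 4 (0.91 log units; beyond the scatter) separates pyrazin-2-yl from 6-methylpyridin-2-yl, although both are six-membered rings joined through carbon. No accompanying measurement accounts for these differences.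

The compounds shown leave open whether the gap between compound 1 and compound 4 belongs to the methyl group or to the ring nitrogens, since these two groups differ in both at once. An unsubstituted pyridin-2-yl or a 6-methylpyrazin-2-yl at this position would separate the two, and a plain phenyl ring would show what the shared core gives with no ring nitrogen there at all.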